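The source may hold more compounds than are shown below. What is called first, only, known or untested is meant among the compounds shown, and "the series" means these compounds.

Compound 1 `CC(=O)OCCc1c(C)[nH]c(=O)[nH]c1=O` reaches, in a functional assay on MOLT-4 cells (Homo sapiens) for antiproliferative activity, read by MTT assay, with a stated time of 24 h (on this read-out higher numbers stand for weaker inhibition and lower numbers for stronger inhibition), only the assay limit of > 100000 nM, so its true potency is not resolved by the measurement. Compound 2 `CC(=O)OCCc1c(C)nc(Cl)nc1Cl` likewise gives only the limit > 100000 nM in this assay. The shared picture is the limit of > 100000 nM in this assay, at which 2 of the 2 values shown sit. Compound 3 `Cc1[nH]c(=O)[nH]c(=O)c1CCCl` differs from compound 1 by chloro in place of acetoxy on a saturated chain carbon, two bonds along the chain from an aromatic carbon. Within the data shown here, no measured pair shows this change, so its size cannot be read from the data; compound 3 is expected to stay near the limit, with a step of a number no higher from compound 1 to compound 3 (the limit leaves the size open) in this assay. In this assay compound 3 is estimated at 100000 nM, between 30000 nM and 300000 nM.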

Compound 3, half-maximal inhibitory concentration: > 100000 nM
Compound 3: no number, only a limit (the forecaster's own chance of this, stated with the estimate: 70%); the middle value sits exactly at the limit.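

Compound 1 and compound 3 both give only a limit, so no step between them can be read: the limit of > 100000 nM in this assay, at which 3 of the 3 values shown sit.

The compounds shown leave open whether any change on the shared core gives a resolved number in this assay.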